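The compounds below may be only part of what the source reports. "The series", "measured", "known", "first", "only" and "open" are said of these compounds alone.

Measured so far in an ADME assay on Vero cells (Chlorocebus sabaeus) for cytotoxicity, read by MTT assay, with a stated time of 72 h; a higher number here means that more compound is tolerated, a lower number that less compound is tolerated:
- compound 1 `N/C(=N/NC(CC(=O)c1ccc(-n2ccnc2)cc1)c1ccc(F)cc1)c1ccccn1` gives 78800 nM
- compound 2 `N/C(=N/NC(CC(=O)c1ccc(-n2ccnc2)cc1)c1ccc([N+](=O)[O-])cc1)c1ccccn1` gives 23100 nM

Compound 2 holds the lowest of the two numbers in this assay; its nearest neighbour is compound 1, and that gap is the step of a 3.4-fold lower number from compound 1 to compound 2 (0.53 log units; beyond the scatter), which lies beyond the scatter.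

Compound 3 `N/C(=N/NC(CC(=O)c1ccc(-n2ccnc2)cc1)c1ccc(Br)cc1)c1ccccn1` is not yet measured. It differs from compound 2 by bromo in place of nitro on an aromatic carbon.

For the measured compounds named here, no measured step bears directly on this change; the only step, a 3.4-fold lower number from compound 1 to compound 2 (0.53 log units; beyond the scatter), runs from fluoro to nitro and is modest. That step shows the nitro compound with the lower number and the fluoro compound with the higher one, and bromo is neither. A value somewhere between compound 1 and compound 2 is therefore expected, with the step of a 1.9-fold higher number from compound 2 to compound 3 (0.29 log units; within the scatter) taken as the working guess. For compound 3 the estimate is 45000 nM, within the range 15000 nM to 120000 nM.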

Compound 3, half-maximal cytotoxic concentration: 298000 nM
The estimate for compound 3 lay 6.6-fold (0.82 log units) below the measured number; the measured number lies above the stated range.
By their numbers in this assay, from the lowest: compound 2; then compound 1; then compound 3.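

In this assay, bromo in place of nitro gives a 13-fold higher number from compound 2 to compound 3 (1.11 log units; beyond the scatter) and is a large step, while bromo in place of fluoro gives a 3.8-fold higher number from compound 1 to compound 3 (0.58 log units; beyond the scatter) and is a modest one; both lie beyond the scatter. Compound 3 therefore has the highest number of the three, and the 4-substituted phenyl position can move the number well past compound 1 as well as below it, which the fluoro and nitro pair alone did not show. Nothing available accounts for the order nitro, fluoro, bromo.

Where chloro or iodo would stand in this order stays open, as does the place of a methoxy group, an amine or a carboxylic acid on the same carbon. All three compounds vary this one place, so how the rest of the shared core contributes cannot be read.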